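From Bromo to Ethoxy on the Aryl Ketone

A few compounds are considered here, and "the series" means these few. Any claim that something is new, unique, unknown or untested is made for them only; others in the source may bear on it.

In a functional assay on L1210 cells (Mus musculus) for antiproliferative activity, with a stated time of 48 h (a higher number here means a weaker inhibitor, a lower number a stronger inhibitor), compound 1 `C=C(Br)C(=O)Nc1ccc(/C=C/C(=O)c2ccc(Cl)c(Cl)c2)cc1` gives 2100 nM, compound 2 `C=C(Br)C(=O)Nc1ccc(/C=C/C(=O)c2ccc(Br)cc2)cc1` gives 620 nM and compound 3 `C=C(Br)C(=O)Nc1ccc(/C=C/C(=O)c2cccc(OC)c2)cc1` gives 2100 nM. Compound 2 has the lowest number of the three, while the other two do not separate, with no change at the digits printed from compound 1 to compound 3 (within the scatter).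

Compound 4 `C=C(Br)C(=O)Nc1ccc(/C=C/C(=O)c2ccc(OCC)cc2)cc1` has not yet been measured. It differs from compound 2 by having ethoxy in place of bromo on an aromatic carbon, para to a large group: ethoxy in place of bromo on an aromatic carbon.

Going by the values given here, no measured compound carries ethoxy, so the evidence is indirect. Among the compounds with values here, two steps bear on the change, both involving the 4-bromophenyl of compound 2: a 3.4-fold lower number from compound 1 to compound 2 (0.53 log units; beyond the scatter) and a 3.4-fold higher number from compound 2 to compound 3 (0.53 log units; beyond the scatter). The second is the nearer guide, since compound 3 has 3-methoxyphenyl in place of 4-bromophenyl, although that is not the same substitution. A modest move to a higher number is therefore expected in this assay, and the expected change is a 2.1-fold higher number from compound 2 to compound 4 (0.32 log units; beyond the scatter). The estimated value for compound 4 is 1300 nM, with an expected range from 450 nM to 3200 nM.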

Compound 4, half-maximal inhibitory concentration: 240 nM
Beside the measured number, compound 4's estimate is 5.4-fold (0.73 log units) above it; the whole stated range lies above it.
By their numbers in this assay, from the lowest: compound 4; then compound 2; then compounds 1 and 3 (each within the scatter of the next).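

In this assay, going by these compounds alone, ethoxy in place of bromo on this aromatic carbon, para to a large group, gives a 2.6-fold lower number from compound 2 to compound 4 (0.41 log units; beyond the scatter) and puts compound 4 ahead of compound 2, which had the lowest number among the earlier compounds. Within the data shown here, those compounds showed only that the 4-bromophenyl of compound 2 stood apart from the aryl groups of compounds 1 and 3. This step shows that bromo is not the limit at this position: a group of three heavy atoms, joined through oxygen, goes with a lower number than the single bromine. No measurement shown here accounts for the step.

Going by these compounds, whether the number keeps falling with a longer chain such as propoxy or butoxy stays open. So does how methoxy, an amine or a carboxylic acid would fare at this same position.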